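Two chlorines in place of one on the shared core

A few compounds are considered here, and "the series" means these few. Any claim that something is new, unique, unknown or untested is made for them only; others in the source may bear on it.

This account follows one step in a small set of three measured compounds. Compound 1 `ClCc1ccc(Cn2cnc3c(Cl)ncnc32)cc1` gives 5370 nM in a functional assay on SN12C cells (Homo sapiens) for cytotoxicity, read by sulforhodamine B assay, with a stated time of 48 h; on this read-out higher numbers stand for lower toxicity in this test and lower numbers for higher toxicity in this test. Compound 2 `Nc1nc(Cl)c2ncn(Cc3ccccc3CCl)c2n1` gives 19500 nM in this assay, which places it as the second highest of the three numbers, with compound 3 `ClCc1ccccc1Cn1cnc2ncnc(Cl)c21` nearest at 42700 nM, a gap beyond the scatter, and compound 1 furthest, also beyond the scatter.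

The step under consideration leads from compound 2 to compound 4 `ClCc1ccccc1Cn1cnc2c(Cl)nc(Cl)nc21`, which has not yet been measured in this assay. The change is chloro in place of amino on an aromatic carbon. In words, it is chloro in place of amino on an aromatic carbon, the carbon that sits between two ring nitrogen atoms of the fused system.

For the measured compounds named here, no two measured compounds differ in only this place, so the direction of the step has to be expected rather than read off. Compound 3, which carries no amino group, gives 42700 nM, a higher number than compound 2, but it also lacks the second chloro, so it is only a loose pointer. The step from compound 2 to compound 4 is expected to be a 1.3-fold higher number from compound 2 to compound 4 (0.11 log units; within the scatter), a modest shift toward a higher number that may not clear the scatter. Compound 4 is therefore estimated at 25000 nM, within a range of 8000 nM to 70000 nM.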

Compound 4, concentration lethal to 50% of the cells: 4670 nM
For compound 4 the middle estimate is 5.4-fold (0.73 log units) above the measured one; the measured number lies below the stated range.
By their numbers in this assay, from the lowest: compounds 4 and 1 (each within the scatter of the next); then compound 2; then compound 3.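

In this assay, putting chloro in place of amino on the aromatic carbon between two ring nitrogen atoms gives a 4.2-fold lower number from compound 2 to compound 4 (0.62 log units; beyond the scatter), a modest step beyond the scatter and toward higher toxicity in this test. For the compounds shown here, this is the first pair in the set that differs in one place only, so it is the first direct sign that this position responds to the change, something compound 1 and compound 3 could only hint at loosely. Nothing measured here accounts for the size or direction of the step.

The compounds shown leave open how other groups on this carbon would read, such as a methoxy group, a methylamino group or a fluoro group, as only amino and chloro appear there. They also leave open whether the same exchange would move the number in the same direction on the frameworks of compound 1 and compound 3, which carry neither amino nor chloro on this carbon.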